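The source may hold more compounds than are shown below. What is called first, only, known or untested is meant among the compounds shown, and "the series" means these compounds.

Values in an ADME assay on RAW264.7 cells (Mus musculus) for cytotoxicity, read by MTT assay, with a stated time of 24 h (on this read-out lower numbers stand for higher toxicity in this test and higher numbers for lower toxicity in this test), so far, with the unmeasured compound last

- Compound 1 `CC/C=C\C[C@H]1C(=O)C=C[C@H]1CC(=O)OCCCC` gives 31 uM
- Compound 2 `CC/C=C\C[C@H]1C(=O)C=C[C@H]1CC(=O)OCc1ccccc1` gives 31 uM
- Compound 3 `CC/C=C\C[C@H]1C(=O)C=C[C@H]1CC(=O)OCCO` gives 161 uM
- Compound 4 `CC/C=C\C[C@H]1C(=O)C=C[C@H]1CC(=O)OCCOCCOCCO` has no value yet

Compound 3 has the highest number of the three, so it is the least toxic in this assay. Compound 4 differs from it by one change, (2-(2-hydroxyethoxy)ethyl in place of hydrogen on an oxygen on a saturated carbon), which is 2-(2-hydroxyethoxy)ethyl in place of hydrogen on an oxygen on a saturated carbon.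

Among the compounds with values here, two measured steps bear on this change, a 5.2-fold higher number from compound 1 to compound 3 (0.72 log units; beyond the scatter) and a 5.2-fold higher number from compound 2 to compound 3 (0.72 log units; beyond the scatter). The third step shows no change at the digits printed from compound 1 to compound 2 (within the scatter). Both steps that bear on it end at compound 3, and neither extends a chain that already carries a hydroxy group, so they offer only a rough guide. Compound 4 still carries a hydroxy group, so its number should stay high.

The estimate is a small rise, perhaps none beyond the scatter, expected as a 1.4-fold higher number from compound 3 to compound 4 (0.14 log units; within the scatter). Compound 4 is expected near 220 uM, with an estimated range from 100 uM to 500 uM.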

Compound 4, half-maximal toxic concentration: 162 uM
Compound 4: middle estimate off by 1.4-fold (0.13 log units), on the high side; low and high end bracket the measured number.
By their numbers in this assay, from the lowest: compounds 1 and 2 (each within the scatter of the next); then compounds 3 and 4 (each within the scatter of the next).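

In this assay, putting 2-(2-hydroxyethoxy)ethyl in place of hydrogen on the oxygen of compound 3 gives a 1.0-fold higher number from compound 3 to compound 4 (0.00 log units; within the scatter), so this position accepts a much longer chain with no shift beyond the scatter. The gain over the two compounds without a hydroxy group also survives that extension, with a 5.2-fold higher number from compound 1 to compound 4 (0.72 log units; beyond the scatter) and a 5.2-fold higher number from compound 2 to compound 4 (0.72 log units; beyond the scatter), and none of the four compounds goes against this. No measurement shown here explains the result.

From the compounds shown here alone, what stays open is whether the hydroxy group itself matters, or whether any chain with oxygens in it would do; a 2-methoxyethyl ester would separate the two. Also open, going by these compounds, is how an amine or a carboxylic acid in place of that hydroxy group would read in this assay.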